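Swapping the aryl group on the ring nitrogen once more

A few compounds are considered here, and "the series" means these few. Any claim that something is new, unique, unknown or untested is made for them only; others in the source may bear on it.

Three compounds share one core and differ only in the aryl group that sits on a nitrogen on an aromatic ring in a ring. Compound 1 `CC(C)OC(=O)N1CCC(Oc2ncnc3c2CCN3c2ccc(S(C)(=O)=O)cc2F)CC1` gives 91% in a functional assay on CHO-K1 cells with Glucose-dependent insulinotropic receptor (Homo sapiens) as the target, read by a luciferase reporter, with a stated time of 5 h; a higher number here means a larger maximal response, a lower number a smaller maximal response. Compound 2 `CC(C)OC(=O)N1CCC(Sc2ncnc3c2CCN3c2ccc(S(C)(=O)=O)cc2F)CC1` gives 69% in the same assay. Compound 3 `CC(C)OC(=O)N1CCC(Oc2ncnc3c2CCN3c2ccc(S(C)(=O)=O)cn2)CC1` gives 111%, which is the highest of the three numbers; its nearest neighbour is compound 1, and compound 2 lies furthest below it. Among the compounds with values here, the one step that bears on the present question is a number 20 percentage points higher from compound 1 to compound 3 (beyond the scatter), where 5-(methylsulfonyl)pyridin-2-yl took the place of 2-fluoro-4-(methylsulfonyl)phenyl on that nitrogen: a modest rise, beyond the scatter. So the aryl group on that nitrogen does shift the maximal response.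

Within the data shown here, compound 4 `CC(C)OC(=O)N1CCC(Oc2ncnc3c2CCN3c2ccc(C#N)c(F)c2)CC1` makes a second change at the same place: 4-cyano-3-fluorophenyl in place of 5-(methylsulfonyl)pyridin-2-yl on a nitrogen on an aromatic ring in a ring The group entering, 4-cyano-3-fluorophenyl, matches neither of the two measured aryl groups, and no measured step shows what a nitrile at that position does. Among the measured compounds shown here, because a number 20 percentage points higher from compound 1 to compound 3 (beyond the scatter) was modest and is the only guide, the estimate for compound 4 is a value near that of compound 1, an expected step of a number 21 percentage points lower from compound 3 to compound 4 (beyond the scatter), giving an estimated 90% with a range from 65% to 115%.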

Compound 4, largest response reached (reported as percent of maximum), in percent of the reference or control that the assay uses: 121%
Compound 4: middle estimate off by 31 percentage points, on the low side, and the stated range ends below it.
By their numbers in this assay, from the lowest: compound 2; then compound 1; then compounds 3 and 4 (each within the scatter of the next).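

In this assay, the change from 5-(methylsulfonyl)pyridin-2-yl to 4-cyano-3-fluorophenyl gives a number 10 percentage points higher from compound 3 to compound 4 (within the scatter), so this place on the nitrogen tolerates a quite different group without a measurable change in maximal response: a carbon-only ring with a nitrile matches a pyridine ring with a methylsulfonyl group. The comparison with the other methylsulfonyl compound gives a number 30 percentage points higher from compound 1 to compound 4 (beyond the scatter), which shows that a methylsulfonyl group is not needed for the higher response and, with compound 1 and compound 3 both carrying one yet lying apart, does not settle the response by itself. Nothing available here explains why these aryl groups give the responses they do.

The compounds shown leave open whether the nitrile or the fluorine in 4-cyano-3-fluorophenyl matters more, and whether a plain phenyl ring, or a phenyl ring carrying a carboxylic acid or an amine, would keep the response. As far as these compounds go, it also remains open whether 4-cyano-3-fluorophenyl would give a similar response on the core of compound 2, which has sulfur in place of the oxygen.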